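Trimming the benzyl group from a coumarin propargylamine

This account rests on a few compounds, and the source may have more. Where it says the series, first, only, none or still open, it means among the compounds named here.

The three measured compounds share a coumarin core carrying a chain to a propargylamine nitrogen. Among the measured compounds shown here, compound 1 `C#CCN(CCCCOc1ccc2ccc(=O)oc2c1)Cc1ccc(C(C)C)cc1` gives 3500 nM in an assay on isolated protein for inhibition of Amine oxidase [flavin-containing] B (Homo sapiens), read by fluorescence and Amplex Red, with stated times of 15 min and 20 min; on this read-out higher numbers stand for weaker inhibition and lower numbers for stronger inhibition; compound 3 `C#CCN(CCCCOc1ccc2ccc(=O)oc2c1)Cc1ccc(F)c(F)c1` gives 2370 nM, and the only single-point step, a 1.5-fold lower number from compound 1 to compound 3 (0.17 log units; within the scatter), shows how little the aryl substituent pattern moved the number. Compound 2 `C#CCN(CCCOc1ccc2ccc(=O)oc2c1)Cc1cccc(F)c1` gives 4440 nM, the highest of the three numbers, though its gaps to compound 1 and to compound 3 both lie within the scatter.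

Compound 4 `C#CCN(C)CCCOc1ccc2ccc(=O)oc2c1` has not been measured. Its change from compound 2 is hydrogen in place of 3-fluorophenyl on a saturated chain carbon bound to an amine nitrogen, so the whole 3-fluorophenyl is lost and the nitrogen keeps only a methyl beside the propargyl. For the measured compounds named here, no measured step removes an aryl group outright; the one step at this position only swaps one aryl for another and stays within the scatter. A loss of the aromatic ring is therefore expected to raise the number, by a 2.5-fold higher number from compound 2 to compound 4 (0.39 log units; beyond the scatter) as an estimate. Compound 4 is expected to give about 11000 nM, within 3000 nM to 40000 nM.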

Compound 4, half-maximal inhibitory concentration: 1090 nM
Compound 4: the middle estimate sits 10-fold (1.00 log units) above what was measured; measured number below the stated range.
By their numbers in this assay, from the lowest: compound 4; then compounds 3, 1 and 2 (each within the scatter of the next).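

In this assay, among the compounds shown here, exchanging 3-fluorobenzyl for methyl on the amine nitrogen gives a 4.1-fold lower number from compound 2 to compound 4 (0.61 log units; beyond the scatter), the first step at this position that lies beyond the scatter. The earlier step only swapped one aryl group for another, whereas this one removes the aromatic ring outright and shows that, on the chain of compound 2, inhibition does not depend on keeping that ring and is in fact stronger without it. Nothing measured here accounts for this change.

The compounds shown leave open whether the lower number follows the loss of the ring or simply the smaller group on the nitrogen, a question that an ethyl or an unsubstituted benzyl group on the same chain would address. On these data alone, it also remains open whether methyl has the same effect on the longer chain of compound 1 and compound 3.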